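Working notes: cytotoxicity of a shared core toward compound 4

A few compounds are considered here, and "the series" means these few. Any claim that something is new, unique, unknown or untested is made for them only; others in the source may bear on it.

Of the compounds shown here, three of one shared core have been read in an ADME assay on CRL8155 cells (Homo sapiens) for cytotoxicity, read by resazurin assay, with a stated time of 72 h; on this read-out higher numbers stand for an effect only at larger amounts of compound and lower numbers for an effect already at smaller amounts. Compound 1 `O=C(c1ccccc1)c1ccc2nc(NCCC3CCCNC3)[nH]c2c1` reaches only the limit of that assay, > 30000 nM. Compound 2 `O=C(NCCO)Nc1nc2cc(C(=O)c3ccccc3)ccc2[nH]1` likewise stops at a limit, > 30000 nM. Compound 3 `O=C(NCCC1CCNCC1)Nc1nc2ccc(C(=O)c3ccccc3)cc2[nH]1` also gives only a limit, > 30000 nM, so no number is known for it. Where compound 3 stands cannot be ordered against the others: all three values shown sit at the limit of > 30000 nM in this assay, at which 3 of the 3 values shown sit, and nothing separates them.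

Compound 4 `O=C(CCCC1CCNCC1)Nc1nc2ccc(C(=O)c3ccccc3)cc2[nH]1` is the next member, not yet read in this assay. It differs from compound 3 in one place: 3-(piperidin-4-yl)propyl in place of (2-(piperidin-4-yl)ethyl)amino on a carbonyl carbon. For the measured compounds named here, no step between two measured compounds exists, so the size of this change cannot be read from a neighbouring pair. With every measured value sitting at the limit, as the limit of > 30000 nM in this assay, at which 3 of the 3 values shown sit, records, the expected step in this assay is none beyond the scatter, a number no higher from compound 3 to compound 4 (the limit leaves the size open). Compound 4 is accordingly estimated at 30000 nM, within a range of 15000 nM to 60000 nM, and the most likely outcome is that this assay again reports only a limit for compound 4.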

Compound 4, half-maximal effective concentration: > 30000 nM
Compound 4: no number, only a limit; the forecaster's own chance of this, stated with the estimate: 80%; the middle value sits exactly at the limit.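

No step can be read from compound 3 to compound 4, as both give only a limit: the limit of > 30000 nM in this assay, at which 4 of the 4 values shown sit.

The compounds shown leave open at what concentration any of them affects these cells, and whether 3-(piperidin-4-yl)propyl in place of (2-(piperidin-4-yl)ethyl)amino on a carbonyl carbon alters that concentration at all.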